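The source may report more compounds than this note shows. Statements on the series, on what has been measured and on what is new or still open speak of the compounds shown alone.

Measured in a physicochemical assay for solubility, in phosphate buffer, with a stated time of 18 h, at pH 7.4; a higher number here means a more soluble compound, a lower number a less soluble compound:
- compound 1 `COc1cc2ncnc(-n3nc(-c4ccccn4)nc3N)c2cc1[N+](=O)[O-]`: 2000 nM
- compound 2 `COc1cc2ncnc(-n3nc(-c4ccccn4)nc3N)c2cc1N`: 3000 nM
- compound 3 `COc1cc2ncnc(-n3nc(-c4ccccn4)nc3N)c2cc1OCCCNC(=O)OC(C)(C)C`: 2000 nM

Compound 3 gives the same reading as compound 1 and lies within the scatter of compound 2. Compound 4 `CCOC(=O)NCCCOc1cc2c(-n3nc(-c4ccccn4)nc3N)ncnc2cc1OC` carries ethyl in place of tert-butyl on an oxygen next to a carbonyl group. Among the measured compounds shown here, no measured step alters that group alone. The nearest evidence is the introduction of the whole 3-((tert-butoxycarbonyl)amino)propoxy group: no change at the digits printed from compound 1 to compound 3 (within the scatter) and a 1.5-fold lower number from compound 2 to compound 3 (0.18 log units; within the scatter), both within the scatter. No shift beyond the scatter is therefore expected in this assay, and the estimated step is a 1.3-fold higher number from compound 3 to compound 4 (0.10 log units; within the scatter). Compound 4 is estimated at 2500 nM, with an expected range of 1000 nM to 6000 nM.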

Compound 4, solubility: 16000 nM
For compound 4 the middle estimate is 6.4-fold (0.81 log units) below the measured one, and the stated range ends below it.
By their numbers in this assay, from the lowest: compounds 1, 3 and 2 (each within the scatter of the next); then compound 4.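

In this assay, among the compounds shown here, ethyl in place of tert-butyl on an oxygen next to a carbonyl group gives an 8.0-fold higher number from compound 3 to compound 4 (0.90 log units; beyond the scatter), the first step in this short set to lie beyond the scatter. The whole 3-((ethoxycarbonyl)amino)propoxy group gives a 5.3-fold higher number from compound 2 to compound 4 (0.73 log units; beyond the scatter) and an 8.0-fold higher number from compound 1 to compound 4 (0.90 log units; beyond the scatter), whereas its tert-butoxy counterpart stayed within the scatter of both, so the chain as such does not account for the shift. Nothing available bears on the reason for this step.

As far as these compounds go, whether methyl on that oxygen, a free amine at the chain end or a longer chain would read like compound 4 or like compound 3 remains open.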